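Diarylheptanoid enaminones: cyclohexyl to isobutyl on the amine

This account rests on a few compounds, and the source may have more. Where it says the series, first, only, none or still open, it means among the compounds named here.

Measured so far in a functional assay on Caco-2 cells (Homo sapiens), read by fluorescence, tested at 1 uM; on this read-out higher numbers stand for a weaker effect at the one concentration tested and lower numbers for a stronger effect:
compound 1, `COc1cc(/C=C/C(=O)/C=C(/C=C/c2ccc(OC(C)=O)c(OC)c2)NC2CCCCC2)ccc1OC(C)=O`, gives 89%
compound 2, `C=CCNC(=C\C(=O)/C=C/c1ccc(O)c(OC)c1)/C=C/c1ccc(O)c(OC)c1`, gives 89%
compound 3, `CC(C)CNC(=C\C(=O)/C=C/c1ccc(O)cc1)/C=C/c1ccc(O)cc1`, gives 100%

Compound 1 stands level with compound 2 at the digits printed; the two are the lowest of the three numbers, and the gap between them lies within the scatter, so no order between compound 1 and compound 2 can be read. Compound 3 sits higher than compound 1 by a gap beyond the scatter, and compound 3 also differs from compound 1 in the amine substituent and on both aryl rings, so no single change can be credited for that gap. Within the data shown here, no pair of the measured compounds differs in one place only, so no step of known size is available in this assay.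

Compound 4, `COc1cc(/C=C/C(=O)/C=C(/C=C/c2ccc(OC(C)=O)c(OC)c2)NCC(C)C)ccc1OC(C)=O`, is the next compound to be run. Its difference from compound 1 is isobutyl in place of cyclohexyl on an amine nitrogen. Among the measured compounds shown here, since the measured compounds give no step of this kind, the size expected for this change is taken as small, in either direction, and not beyond the scatter. The step expected is a number 4 percentage points higher from compound 1 to compound 4 (within the scatter), a change within the scatter. Compound 4 is therefore estimated at 93%, with a range from 80% to 105%.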

Compound 4, a percentage reported as activity, at one concentration (the size of the read-out at that concentration, not a potency): 96%
Estimate against measurement, compound 4: 3 percentage points below; measured number inside the range.
By their numbers in this assay, from the lowest: compounds 1, 2, 4 and 3 (each within the scatter of the next, the first and the last beyond it).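

In this assay, the series now has its first step between compounds that differ in one place: isobutyl in place of cyclohexyl on an amine nitrogen gives a number 7 percentage points higher from compound 1 to compound 4 (within the scatter) and leaves the rest of compound 1 untouched. At this amine nitrogen, then, an open branched chain can stand in for the six-membered carbon ring with no effect that can be told apart from the scatter, so the ring is not shown to be needed for the read-out at the one concentration tested. No measurement is available that would account for the size of this step.

From the compounds shown here alone, whether this position tolerates change more widely remains open, since a single pair of small carbon-only groups says nothing about a benzyl group, a longer chain such as n-hexyl, or a chain ending in a carboxylic acid. Going by these compounds, it is also open whether the same exchange of cyclohexyl for isobutyl would give a similar step on a core with different aryl substituents, or whether any amine substituent can move the number beyond the scatter.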